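Trimming One Side Branch of Compound 3

A few compounds are considered here, and "the series" means these few. Any claim that something is new, unique, unknown or untested is made for them only; others in the source may bear on it.

Of the compounds shown here, three built on a shared core have been measured in an ADME assay on L02 cells (Homo sapiens) for antiproliferative activity, read by MTT assay, with a stated time of 48 h; a higher number here means a weaker inhibitor, a lower number a stronger inhibitor. Compound 1 `CCN(CC)CCNC(=O)c1ccc(C(CC)(CC)c2ccc(OCCC(O)(CC)CC)c(C)c2)n1CC` gives 2290 nM, the lowest number of the three. Compound 2 `CCn1c(C(=O)N(CCC#N)CCC#N)ccc1C(CC)(CC)c1ccc(OCCC(O)(CC)CC)c(C)c1` gives 37800 nM, the highest. Compound 3 `CCC(C)C(NC(=O)c1ccc(C(CC)(CC)c2ccc(OCCC(O)(CC)CC)c(C)c2)n1CC)C(=O)O` gives 9990 nM, which places it in the middle, with clear gaps on both sides.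

The unmeasured compound 4 `CCn1c(C(=O)NC(C)C(=O)O)ccc1C(CC)(CC)c1ccc(OCCC(O)(CC)CC)c(C)c1` differs from compound 3 in one small place: methyl in place of sec-butyl on a saturated chain carbon bound to an amide-type nitrogen and a carbonyl carbon. The carboxy group stays, as the names 1-carboxy-2-methylbutyl and 1-carboxyethyl show.

For the measured compounds named here, no measured pair makes this exact change. The nearest evidence comes from two much larger swaps of the whole group on the amide: a 4.4-fold higher number from compound 1 to compound 3 (0.64 log units; beyond the scatter), and a 3.8-fold lower number from compound 2 to compound 3 (0.58 log units; beyond the scatter). Both of these modest steps replaced far more than one branch, so a smaller step is expected here, perhaps within the scatter. The direction cannot be settled from these data, with only a slight lean towards a higher number. The estimated change is a 1.3-fold higher number from compound 3 to compound 4 (0.11 log units; within the scatter). For compound 4 the expected value is 13000 nM, with an estimated range of 4500 nM to 38000 nM.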

Compound 4, half-maximal inhibitory concentration: 4040 nM
Compound 4: the middle estimate sits 3.2-fold (0.51 log units) above what was measured; measured number outside the range, below it.
By their numbers in this assay, from the lowest: compounds 1 and 4 (each within the scatter of the next); then compound 3; then compound 2.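

In this assay, cutting sec-butyl back to methyl on this saturated chain carbon, with the carboxy group kept, gives a 2.5-fold lower number from compound 3 to compound 4 (0.39 log units; beyond the scatter), so the number responds to the trimming of this one branch and not only to swaps of the whole group on the amide. The wider comparisons shift as well: a 9.4-fold lower number from compound 2 to compound 4 (0.97 log units; beyond the scatter) is a larger gap than compound 3 had from compound 2, while a 1.8-fold higher number from compound 1 to compound 4 (0.25 log units; within the scatter) shows that, with 1-carboxyethyl on the amide-type nitrogen, a carboxy group does not keep compound 4 apart from compound 1, which carries 2-(diethylamino)ethyl there. Nothing available here accounts for the effect of trimming this branch.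

From the compounds shown here alone, with only sec-butyl and methyl on this carbon, it remains unknown whether an ethyl group, a longer chain or a plain hydrogen would continue the same trend or break it. Going by these compounds, it also remains open whether the number would hold if an ester or a primary amide replaced the carboxylic acid on the 1-carboxyethyl group.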